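Replacing a Hydroxylated Ring with a Non-Aromatic Dione Ring

The source may hold more compounds than are shown below. What is called first, only, known or untested is meant among the compounds shown, and "the series" means these compounds.

Measured compounds:
Compound 1, `NS(=O)(=O)c1ccc(-n2nc(-c3ccc(Cl)cc3)cc2-c2cc(O)ccc2O)cc1`, gives 15100 nM in a functional assay on cells (Cancer cell lines, Homo sapiens) for cytotoxicity, read by sulforhodamine B assay, with a stated time of 48 h; a higher number here means a weaker inhibitor of growth, a lower number a stronger inhibitor of growth.
Compound 2, `CC(=O)NS(=O)(=O)c1ccc(-n2nc(-c3ccccc3)cc2-c2cc(O)ccc2O)cc1`, gives 78600 nM in this assay.
Compound 3, `NS(=O)(=O)c1ccc(-n2nc(-c3ccc(Cl)cc3)cc2C2=CC(=O)C=CC2=O)cc1`, gives 17600 nM in this assay.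

Compound 1 and compound 3 differ in one place: a group of 8 heavy atoms (6 carbon, 2 oxygen; one six-membered non-aromatic ring of carbon only) in place of a group of 8 heavy atoms (6 carbon, 2 oxygen; one six-membered aromatic ring of carbon only), on an aromatic carbon. This change gave a 1.2-fold higher number from compound 1 to compound 3 (0.07 log units; within the scatter), so in this pair the swap of the aromatic ring for the non-aromatic one left the growth inhibition essentially unchanged.

Compound 2 stands apart from the other two. Its value is the highest of the three, and the difference between the core of compound 2 and the core of compound 1 is not broken down here.

Compound 4, `CC(=O)NS(=O)(=O)c1ccc(-n2nc(-c3ccccc3)cc2C2=CC(=O)C=CC2=O)cc1`, has not yet been measured. It differs from compound 2 as follows: a group of 8 heavy atoms (6 carbon, 2 oxygen; one six-membered non-aromatic ring of carbon only) in place of a group of 8 heavy atoms (6 carbon, 2 oxygen; one six-membered aromatic ring of carbon only), on an aromatic carbon. Within the data shown here, this is the same kind of change as the one from compound 1 to compound 3, but not the same: in compound 2 the ring atom that bears a large group and the ring atom that bears a phenyl group surround the place, whereas in compound 1 these atoms bear a 4-sulfamoylphenyl group and a 4-chlorophenyl group.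

Because a 1.2-fold higher number from compound 1 to compound 3 (0.07 log units; within the scatter) lay within the scatter, the step of a 1.1-fold higher number from compound 2 to compound 4 (0.03 log units; within the scatter) is expected to be small as well. Among the measured compounds shown here, compound 4 is therefore estimated at 85000 nM in this assay, with a likely range from 30000 nM to 200000 nM, resting on the single measured step from compound 1 to compound 3 and on the value of compound 2.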

Compound 4, concentration for 50% growth inhibition: 78400 nM
Compound 4: the middle estimate sits 1.1-fold (0.04 log units) above what was measured, and the stated range covers the measured number.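

In this assay, exchanging the 2,5-dihydroxyphenyl group for the non-aromatic six-membered ring gave a 1.0-fold lower number from compound 2 to compound 4 (0.00 log units; within the scatter), so on this core the swap left the number in place, just as it did on the core of compound 1. Set side by side, the two steps show no sign that the outcome of this change depends on which of the two cores carries it: the same change on two cores in this assay, a 1.2-fold higher number (0.07 log units; within the scatter) from compound 1 to compound 3 and a 1.0-fold lower number (0.00 log units; within the scatter) from compound 2 to compound 4, 1.2-fold (0.07 log units) apart, within the scatter of two such steps. This is a small base, however: two pairs support the transfer of the change between these two cores only, and they do not show that it would behave the same way on a core carrying other groups, or in any test other than this one.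

The compounds shown include no pair that differs only in the chlorine or only in the acetyl group, so the part each of these plays in growth inhibition stays open. Also open, from the compounds shown here alone, is whether the swap would hold on a core with a carboxylic acid or an amine in place of the sulfonamide, and whether a ring with methoxy groups in place of the hydroxyl groups would give a similar number.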